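From Trihydroxyphenyl to Bromoindole in a Growth Test

The source may hold more compounds than are shown below. What is called first, only, known or untested is meant among the compounds shown, and "the series" means these compounds.

Measured in a functional assay on DU-145 cells (Homo sapiens) for inhibition, read by trypan blue exclusion, with a stated time of 96 h; on this read-out lower numbers stand for stronger inhibition of growth and higher numbers for weaker inhibition of growth:
- compound 1 `Cc1ccc(CS(=O)(=O)/C(=C/c2c[nH]c3ccccc23)C(=O)c2ccc(Cl)cc2)cc1`: 25000 nM
- compound 2 `Cc1ccc(CS(=O)(=O)/C(=C/c2ccc(N(C)C)cc2)C(=O)c2ccc(Cl)cc2)cc1`: 50000 nM
- compound 3 `Cc1ccc(CS(=O)(=O)/C(=C/c2c(O)cc(O)cc2O)C(=O)c2ccc(Cl)cc2)cc1`: > 100000 nM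

Compound 3 has no exact number, only a limit of the assay: > 100000 nM.

The next compound to be measured is compound 4 `Cc1ccc(CS(=O)(=O)/C(=C/c2c[nH]c3ccc(Br)cc23)C(=O)c2ccc(Cl)cc2)cc1`. In it, 5-bromo-1H-indol-3-yl takes the place of 2,4,6-trihydroxyphenyl on a double-bonded chain carbon bound to a double-bonded chain carbon: 5-bromo-1H-indol-3-yl in place of 2,4,6-trihydroxyphenyl on a double-bonded chain carbon bound to a double-bonded chain carbon.

The closest evidence is an at least 4.0-fold higher number from compound 1 to compound 3 (0.60 log units; beyond the scatter), where 2,4,6-trihydroxyphenyl replaces 1H-indol-3-yl. Read backwards, that step favours the indolyl group. The step of an at least 2.0-fold higher number from compound 2 to compound 3 (0.30 log units; that floor lies within the scatter) points the same way but carries less weight. Within the data shown here, no measured compound shows what the bromine adds, so the range must stay wide.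

Compound 1, which has the same group without bromine, gives 25000 nM, and this anchors the expectation. In this assay the expected step is an at least 8.3-fold lower number from compound 3 to compound 4 (0.92 log units; beyond the scatter), towards a lower number and stronger inhibition of growth. For compound 4 the estimated value is 12000 nM, with an expected range from 3000 nM to 40000 nM.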

Compound 4, concentration for 50% growth inhibition: 10000 nM
Compound 4: middle estimate off by 1.2-fold (0.08 log units), on the high side; the range from low to high includes it.
By their numbers in this assay, from the lowest: compound 4; then compounds 1 and 2 (each within the scatter of the next). At a limit, above all of these: compound 3.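

Replacing hydrogen with bromo on an aromatic carbon gives a 2.5-fold lower number from compound 1 to compound 4 (0.40 log units; beyond the scatter) in this assay, the first sign that a small change on the indolyl group itself can move the result. The 5-bromo-1H-indol-3-yl group also stands clearly apart from the 4-(dimethylamino)phenyl group, with a 5.0-fold lower number from compound 2 to compound 4 (0.70 log units; beyond the scatter), a separation the indolyl group without bromine did not show. Against the 2,4,6-trihydroxyphenyl group the result is an at least 10-fold lower number from compound 3 to compound 4 (1.00 log units; beyond the scatter), which gives only a floor for the size of the step, since compound 3 has no exact number and holds only a limit of the assay: the limit of > 100000 nM in this assay, at which 1 of the 4 values shown sits.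

The compounds shown leave open whether this lower number is specific to bromo or would also come with a fluoro or methoxy group in its place. They also leave open whether bromo would lower the number on the 4-(dimethylamino)phenyl group.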